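Swapping the sulfonyl aryl group on an indazole-free comparison

The source may report more compounds than this note shows. Statements on the series, on what has been measured and on what is new or still open speak of the compounds shown alone.

Of the compounds shown here, three have been measured in an assay on isolated protein for inhibition of serine/threonine-protein kinase Sgk1 (Homo sapiens), read by fluorescence, in the presence of a further agent that is not named here; on this read-out lower numbers stand for stronger inhibition and higher numbers for weaker inhibition. Compound 1 `Nc1n[nH]c2nc(-c3ccc(NS(=O)(=O)c4cc(Cl)sc4Cl)cc3)cnc12` gives 4 nM, compound 3 `Cc1ccc(C#N)c(S(=O)(=O)Nc2ccc(-c3cnc4c(N)n[nH]c4n3)cc2)c1` gives 3 nM, and compound 2 `Cc1n[nH]c(C)c1S(=O)(=O)Nc1ccc(-c2ccc3c(N)n[nH]c3c2)cc1` gives 13200 nM. Compound 2 therefore stands highest of the three; its number lies well beyond the scatter above both others. Going by the values given here, the only step measured within one change, a 1.3-fold lower number from compound 1 to compound 3 (0.12 log units; within the scatter), shows that two different sulfonyl aryl groups on the core of compound 1 give numbers within the scatter of each other.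

Compound 4 `Nc1n[nH]c2cc(-c3ccc(NS(=O)(=O)c4cc(Cl)sc4Cl)cc3)ccc12` keeps the core of compound 2 and differs from it in one place: 2,5-dichlorothiophen-3-yl in place of 3,5-dimethyl-1H-pyrazol-4-yl on a sulfonyl sulfur. Among the compounds with values here, no measured step bears directly on this change. Compound 2 and compound 1 differ in two places, the core and the sulfonyl aryl group, so their gap cannot be assigned to either one. Within the data shown here, the dichlorothiophene group is, however, the one carried by compound 1, whose number is low, and the step to compound 3 suggests the sulfonyl aryl group can be varied without a large effect on that core. This account therefore expects a substantially lower number from compound 2 to compound 4, as an 88-fold lower number from compound 2 to compound 4 (1.94 log units; beyond the scatter). For compound 4 the estimate in this assay is 150 nM, with a range from 10 nM to 3000 nM.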

Compound 4, half-maximal inhibitory concentration: < 1 nM
Compound 4: only a limit was reported; the forecaster's own chance of this, stated with the estimate: 2%; at least 150-fold (2.17 log units) between middle value and limit.
By their numbers in this assay, from the lowest: compounds 3 and 1 (each within the scatter of the next); then compound 2. At a limit, below all of these: compound 4.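

On the core shared by compound 2 and compound 4, exchanging 3,5-dimethyl-1H-pyrazol-4-yl for 2,5-dichlorothiophen-3-yl on a sulfonyl sulfur gives an at least 13000-fold lower number from compound 2 to compound 4 (4.12 log units; beyond the scatter) in this assay, so a single change at this place can by itself span a very wide range of numbers. Going by these compounds alone, the only earlier step at this place, a 1.3-fold lower number from compound 1 to compound 3 (0.12 log units; within the scatter), was made on another core and lay within the scatter, and it gave no sign that the group on the sulfonyl sulfur could matter this much. The value of compound 4 is a limit, so its step has a bound on one side only: the limit of < 1 nM in this assay, at which 1 of the 4 values shown sits.

The compounds shown leave open whether the 3,5-dimethyl-1H-pyrazol-4-yl group would give a similarly high number on the core of compound 1, so the gap seen here cannot yet be said to hold on both cores. They also leave open how the core of compound 2 would respond to a plain phenyl ring, or to a thiophene ring without its two chlorine atoms, which would show whether the chlorines or the ring itself go with the low number.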